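The compounds below may be only part of what the source reports. "The series", "measured", "known", "first", "only" and "open" are said of these compounds alone.

In a functional assay on ECa-109 cells for inhibition, with ECa-109 cell line (Homo sapiens) as the target, read by sulforhodamine B assay (a higher number here means a weaker inhibitor, a lower number a stronger inhibitor), the measured compounds give:

- compound 1 `CCc1ccc(NC2=CC(=O)c3nc4n(c3C2=O)[C@H]2OC[C@@H](O)[C@H]2OC4)cc1`: 3080 nM
- compound 2 `O=C1C=C(Nc2ccc(C(F)(F)F)cc2)C(=O)c2c1nc1n2[C@H]2OC[C@@H](O)[C@H]2OC1`: 5500 nM
- compound 3 `CCCN(CCC)C1=CC(=O)c2nc3n(c2C1=O)[C@H]1OC[C@@H](O)[C@H]1OC3`: > 16000 nM (a limit, not a number)

Compound 3 stands at the limit of > 16000 nM in this assay, at which 1 of the 3 values shown sits. It therefore has no exact place among the three, and any step starting from it is bounded on one side only.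

Compound 4 `Cc1ccc(NC2=CC(=O)c3nc4n(c3C2=O)[C@H]2OC[C@@H](O)[C@H]2OC4)cc1` has not yet been measured. It replaces the dipropylamino of compound 3 with (4-methylphenyl)amino on a double-bonded ring carbon: (4-methylphenyl)amino in place of dipropylamino on a double-bonded ring carbon. The closest evidence is the opposite kind of exchange, where dipropylamino took the place of (4-ethylphenyl)amino, giving an at least 5.1-fold higher number from compound 1 to compound 3 (0.71 log units; beyond the scatter). Another measured step bears on the group on the aromatic ring: with trifluoromethyl in place of ethyl, the result was a 1.8-fold higher number from compound 1 to compound 2 (0.25 log units; within the scatter). Changing that group therefore did little in this one case, so the methyl of compound 4 is not expected to move the value far from those of the other two arylamino compounds.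

The expected change is a return toward a stronger inhibitor, of an at least 4.5-fold lower number from compound 3 to compound 4 (0.66 log units; beyond the scatter). For compound 4 the estimated value in this assay is 3500 nM, with an expected range of 1500 nM to 8000 nM.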

Compound 4, half-maximal inhibitory concentration: 3480 nM
Compound 4: middle estimate off by 1.0-fold (0.00 log units), on the high side; low and high end bracket the measured number.
By their numbers in this assay, from the lowest: compounds 1, 4 and 2 (each within the scatter of the next). At a limit, above all of these: compound 3.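

In this assay, among the compounds shown here, the arylamino group again gives a stronger inhibitor than dipropylamino on the double-bonded ring carbon (an at least 4.5-fold lower number from compound 3 to compound 4 (0.66 log units; beyond the scatter)), so the loss seen earlier with dipropylamino is not tied to the ethyl group of the one arylamino compound then available for that exchange. The value of compound 3 remains a limit and not a number, which leaves this step bounded on one side only: the limit of > 16000 nM in this assay, at which 1 of the 4 values shown sits. With methyl, ethyl and trifluoromethyl on the aromatic ring, the values stay within the scatter of one another (a 1.6-fold lower number from compound 2 to compound 4 (0.20 log units; within the scatter); a 1.1-fold higher number from compound 1 to compound 4 (0.05 log units; within the scatter)), so across these three groups the exchange on the aromatic ring gives no readable change, while the exchange of the whole amino group does.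

Still open, on these data alone, is whether the aromatic ring or the hydrogen on the nitrogen matters more, a question that a propylamino group, with one chain and that hydrogen kept, or an N-methyl-N-arylamino group could address. As far as these compounds go, it is also open how the aromatic ring would tolerate a substituent of another kind, such as a methoxy group, a carboxylic acid or a longer chain.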